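The compounds below may be only part of what the source reports. "The series", "measured", "known", "first", "only" and "open" are said of these compounds alone.

Four compounds are considered here. Compound 1 `CCn1c(-c2cnc(C)nc2)nc2c(N[C@H]3CCN(C(=O)N4CC(OC)C4)C3)ncnc21` and compound 2 `CCn1c(-c2cnc(C)nc2)nc2c(N[C@H]3CCN(C(=O)[C@H]4C[C@@H](OC)C4)C3)ncnc21` share one core; compound 3 `CCn1c(-c2cnc(C)nc2)nc2c(O[C@H]3CCN(C(=O)N4CC(OC)C4)C3)ncnc21` and the not yet measured compound 4 `CCn1c(-c2cnc(C)nc2)nc2c(O[C@H]3CCN(C(=O)[C@H]4C[C@@H](OC)C4)C3)ncnc21` share another, and the difference between the two cores is not broken down here. In an ADME assay on the whole organism (Rattus norvegicus, strain Wistar Han) for metabolic stability (a lower number here means slower removal, a higher number faster removal of the compound), compound 1 gives 93 mL/min/kg and compound 2 gives 81 mL/min/kg; the change 3-methoxycyclobutyl in place of 3-methoxyazetidin-1-yl on a carbonyl carbon made a 1.1-fold lower number from compound 1 to compound 2 (0.06 log units; within the scatter). In this assay compound 3 gives 25 mL/min/kg, the lowest of the three measured numbers. Compound 4 differs from compound 3 by the same change, (3-methoxycyclobutyl in place of 3-methoxyazetidin-1-yl on a carbonyl carbon), made at the same place. Because the earlier pair showed a 1.1-fold lower number from compound 1 to compound 2 (0.06 log units; within the scatter), compound 4 is expected to stay close to compound 3, with an estimated step of a 1.1-fold lower number from compound 3 to compound 4 (0.04 log units; within the scatter). The estimate for compound 4 in this assay is 23 mL/min/kg, expected to fall between 12 mL/min/kg and 45 mL/min/kg.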

Compound 4, clearance: 19 mL/min/kg
Compound 4: the middle estimate sits 1.2-fold (0.08 log units) above what was measured, and the stated range covers the measured number.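

In this assay, putting 3-methoxycyclobutyl in place of 3-methoxyazetidin-1-yl on the carbonyl carbon gives a 1.3-fold lower number from compound 3 to compound 4 (0.12 log units; within the scatter), so on this core too the change stays within the usual scatter of repeated measurements. The two cores agree, as the steps on them can be told apart by no more than that scatter: the same change on two cores in this assay, a 1.1-fold lower number (0.06 log units; within the scatter) from compound 1 to compound 2 and a 1.3-fold lower number (0.12 log units; within the scatter) from compound 3 to compound 4, 1.1-fold (0.06 log units) apart, within the scatter of two such steps For these two pairs, then, the change carried over from one core to the other with no clear effect on clearance, but two pairs do not make a rule for the whole series.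

Going by these compounds, it remains open whether a longer chain or a group carrying an amine on the same carbonyl carbon would also leave clearance unmoved. On these data alone, how the change behaves on a third core also remains open.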